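Series notes: amine variation on the pyrimidinedione core

The compounds below may be only part of what the source reports. "The series", "measured", "known", "first", "only" and "open" are said of these compounds alone.

Of the compounds shown here, two have been read in an ADME assay on MT4 cells (Homo sapiens) for cytotoxicity, read by MTT assay, with a stated time of 4 days; on this read-out lower numbers stand for higher toxicity in this test and higher numbers for lower toxicity in this test. Compound 1, `Cc1cc(C)cc(Cn2c(=O)cc(N=[N+]=[N-])n(Cc3ccncc3)c2=O)c1`, gives 59000 nM in this assay. Compound 2, `Cc1cc(C)cc(Cn2c(=O)cc(N3CCNCC3)n(Cc3ccccc3)c2=O)c1`, gives 16000 nM in this assay, the lower of the two numbers; its gap to compound 1 lies beyond the usual scatter of repeated measurements. Among the measured compounds shown here, compound 1 and compound 2 differ in more than one place, so only their two values can be set side by side, and no single step between them is drawn.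

Compound 3, `Cc1cc(C)cc(Cn2c(=O)cc(N(C)C)n(Cc3ccccc3)c2=O)c1`, has not yet been measured in this assay. It stands one change away from compound 2: dimethylamino in place of piperazin-1-yl on an aromatic carbon.

Nothing in the measured pair tells how this change acts in this assay. The two measured values set a working range, and compound 3 is expected to fall inside it. From compound 2 the step of a 1.9-fold higher number from compound 2 to compound 3 (0.27 log units; within the scatter) is estimated, toward the higher number, at about the size of the scatter or somewhat beyond it. Compound 3 is expected to give about 30000 nM in this assay, with a range from 10000 nM to 90000 nM.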

Compound 3, half-maximal cytotoxic concentration: 48000 nM
Estimate against measurement, compound 3: 1.6-fold (0.20 log units) below; low and high end bracket the measured number.
By their numbers in this assay, from the lowest: compound 2; then compounds 3 and 1 (each within the scatter of the next).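

With this pair the series gains its first single-change step: in this assay, dimethylamino in place of piperazin-1-yl gives a 3.0-fold higher number from compound 2 to compound 3 (0.48 log units; beyond the scatter). The amine on this aromatic carbon, next to the ring nitrogen and para to the 3,5-dimethylbenzyl group, therefore has a readable effect on this read-out, and the direction of the step points to lower toxicity in this test for the dimethylamino compound. No measurement at hand bears on what lies behind the step.

The change removes the six-membered non-aromatic ring, the second ring nitrogen and the hydrogen-bond donor all at once, so a single step cannot assign the shift to any one of these features. From the compounds shown here alone, whether the number follows ring size, or the open-chain form of the amine, remains open for groups such as morpholin-4-yl, piperidin-1-yl or diethylamino at this position, and it is equally open whether the step would hold with a group other than benzyl at the neighbouring ring nitrogen.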